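Notes on a sulfur-for-oxygen swap, compound 3 to compound 4

The compounds below may be only part of what the source reports. "The series", "measured", "known", "first", "only" and "open" are said of these compounds alone.

Compound 1 `CC/N=C(\S)OC[C@H]1OC(n2cnc3c(NC4CCOC4)ncnc32)[C@H](O)[C@@H]1O`: 33 nM
Compound 2 `O=C(NC1CC1)OC[C@H]1OC(n2cnc3c(NC4CCOC4)ncnc32)[C@H](O)[C@@H]1O`: 209 nM
Compound 3 `O=C(NC1CCC1)OC[C@H]1OC(n2cnc3c(NC4CCOC4)ncnc32)[C@H](O)[C@@H]1O`: 306 nM
Compound 4 `O[C@@H]1[C@@H](CO/C(S)=N/C2CCC2)OC(n2cnc3c(NC4CCOC4)ncnc32)[C@@H]1O`: not yet measured

Compound 3 gives the highest of the three numbers in an assay on DDT1 cells (Cricetulus griseus) for binding affinity to adenosine receptor A1 (Homo sapiens), read by radioligand binding; a lower number here means a stronger inhibitor, a higher number a weaker inhibitor; the step of a 1.5-fold higher number from compound 2 to compound 3 (0.17 log units; within the scatter) lies within the scatter, while a 9.3-fold higher number from compound 1 to compound 3 (0.97 log units; beyond the scatter) is beyond it. Going to compound 4, (a group of 7 heavy atoms (5 carbon, 1 nitrogen, 1 sulfur; one four-membered non-aromatic ring of carbon only) in place of a group of 7 heavy atoms (5 carbon, 1 nitrogen, 1 oxygen; one four-membered non-aromatic ring of carbon only), on an oxygen on a saturated carbon). For the measured compounds named here, no measured step isolates this exchange. The nearest are a 6.3-fold higher number from compound 1 to compound 2 (0.80 log units; beyond the scatter) and a 9.3-fold higher number from compound 1 to compound 3 (0.97 log units; beyond the scatter), which each pair the sulfur-for-oxygen swap with a change of the alkyl group, and a 1.5-fold higher number from compound 2 to compound 3 (0.17 log units; within the scatter) shows the ring size alone changes little. Expected for compound 4 is therefore a sizeable drop, a 6.1-fold lower number from compound 3 to compound 4 (0.79 log units; beyond the scatter). The estimate for compound 4 is 50 nM, with a range from 18 nM to 150 nM.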

Compound 4, inhibition constant: 148 nM
Estimate against measurement, compound 4: 3.0-fold (0.47 log units) below; measured number inside the range.
By their numbers in this assay, from the lowest: compound 1; then compounds 4, 2 and 3 (each within the scatter of the next, the first and the last beyond it).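

In this assay the sulfur-for-oxygen swap now stands alone with the cyclobutyl kept: a 2.1-fold lower number from compound 3 to compound 4 (0.32 log units; beyond the scatter). With the sulfur kept, the alkyl group on the double-bonded nitrogen also counts, as the exchange of ethyl for cyclobutyl gives a 4.5-fold higher number from compound 1 to compound 4 (0.65 log units; beyond the scatter). The sulfur does not set compound 4 clear of the cyclopropyl carbamate, with a 1.4-fold lower number from compound 2 to compound 4 (0.15 log units; within the scatter).

Nothing at hand gives a reason for these steps. Open, as far as these compounds go, is whether the swap reads the same with ethyl or cyclopropyl kept, and how a longer chain or a phenyl ring on that nitrogen would read.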